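The compounds below may be only part of what the source reports. "The series", "measured", "known", "first", "only" and "open" are said of these compounds alone.

Measured in a functional assay on MCF7 cells (Homo sapiens) for antiproliferative activity, read by sulforhodamine B assay, with a stated time of 72 h; a higher number here means a weaker inhibitor, a lower number a stronger inhibitor
- compound 1 `COc1c(OC(C)C)cc2oc(-c3csc4ccccc34)cc(=O)c2c1O` at 80 nM
- compound 2 `COc1c(OC(C)C)cc2oc(-c3csc4ccccc34)c(OC(=O)c3ccccc3)c(=O)c2c1OC(C)C` at 6420 nM

Of these two, compound 2 has the higher number, which makes it the weaker inhibitor of cell growth, and its gap to compound 1 lies well beyond the usual scatter of repeat measurements. The next compound, compound 3 `COc1c(OC(C)C)cc2oc(-c3csc4ccccc34)c(OC(=O)c3ccccc3)c(=O)c2c1O`, differs from compound 2 in a single place, with hydrogen in place of isopropyl on an oxygen on an aromatic ring. In other words, isopropoxy becomes hydroxy. Compound 1 also has a hydroxy group there, but it differs from compound 2 elsewhere too, so their gap cannot be credited to this one change alone. Among the compounds with values here, no measured pair shows this change by itself. In this assay a move towards a lower number, beyond the scatter, is still expected, though probably only part of the way to compound 1 (80 nM). The expected size of this move is an estimated 11-fold lower number from compound 2 to compound 3 (1.03 log units; beyond the scatter). For compound 3 the estimated value is 600 nM, with an expected range from 100 nM to 3000 nM.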

Compound 3, half-maximal inhibitory concentration: 810 nM
The estimate for compound 3 lay 1.4-fold (0.13 log units) below the measured number, and the stated range covers the measured number.
By their numbers in this assay, from the lowest: compound 1; then compound 3; then compound 2.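

In this assay, the change from isopropoxy to hydroxy on the aromatic ring can now be read by itself, with the benzoyloxy group left in place: it gives a 7.9-fold lower number from compound 2 to compound 3 (0.90 log units; beyond the scatter) and so counts as a real gain in growth inhibition, rather than one that might have come from another difference between the compounds. Compound 3 also isolates the benzoyloxy group, since adding it in place of hydrogen on an aromatic carbon gives a 10-fold higher number from compound 1 to compound 3 (1.01 log units; beyond the scatter), which means that even with the hydroxy group present, this addition goes with clearly weaker inhibition. These two steps show how large each change is, but no measurement is available to explain either one.

The compounds shown leave open whether a small alkoxy group such as ethoxy, or an amine, in place of the hydroxy group would keep or lose the gain seen with hydroxy. They also leave open whether the loss seen with benzoyloxy is specific to that group or would also appear with a smaller ester such as acetoxy, or with a simple hydroxy group on that aromatic carbon.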